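Swapping the aryl group on a shared purine-like core

This account rests on a few compounds, and the source may have more. Where it says the series, first, only, none or still open, it means among the compounds named here.

In an assay on CHO cells for displacement of a labelled ligand from adenosine receptor A3 (Homo sapiens), read by scintillation counting, with a stated time of 3 h (a higher number here means a weaker inhibitor, a lower number a stronger inhibitor), compound 2 `Cn1c(-c2ccccc2Cl)nc2c(NC3CCCC3)ncnc21` gives 720 nM. Compound 1 `Cc1ccc(-c2nc3c(NC4CCCC4)ncnc3n2C)cc1` gives 480 nM, and the step of a 1.5-fold higher number from compound 1 to compound 2 (0.18 log units; within the scatter) lies within the scatter, so the two compounds cannot be ranked against each other. Compound 3 `Cn1c(-c2cccnc2)nc2c(NC3CCCC3)ncnc21` differs from compound 2 only in its aryl group: pyridin-3-yl in place of 2-chlorophenyl on an aromatic carbon. Among the measured compounds shown here, the single measured step that bears on such an aryl swap, a 1.5-fold higher number from compound 1 to compound 2 (0.18 log units; within the scatter), stayed within the scatter, so no shift beyond the scatter is expected in this assay. Compound 3 is therefore expected to give about 700 nM, between 250 nM and 2000 nM. This amounts to an expected step of a 1.0-fold lower number from compound 2 to compound 3 (0.01 log units; within the scatter).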

Compound 3, inhibition constant: 11000 nM
Estimate against measurement, compound 3: 16-fold (1.20 log units) below; the measured number lies above the stated range.
By their numbers in this assay, from the lowest: compounds 1 and 2 (each within the scatter of the next); then compound 3.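

The aryl position is not indifferent in this assay: the two carbon-only aryl groups stayed within the scatter of each other, yet pyridin-3-yl brings a 15-fold higher number from compound 2 to compound 3 (1.18 log units; beyond the scatter) and a 23-fold higher number from compound 1 to compound 3 (1.36 log units; beyond the scatter). Of the three groups, only pyridin-3-yl has a hetero atom in its six-membered aromatic ring and a hydrogen-bond acceptor. Nothing measured here accounts for this shift.

As far as these compounds go, whether a plain phenyl or a pyridin-4-yl group would give a number close to those of compound 1 and compound 2, or close to that of compound 3, stays open.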